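A Methyl Added to the Chain Between Ring and Amine

The source may hold more compounds than are shown below. What is called first, only, known or untested is meant among the compounds shown, and "the series" means these compounds.

Of the compounds shown here, two share a core and have been measured in an in vivo ADME assay on the whole organism (Rattus norvegicus, strain Sprague Dawley) for pharmacokinetics; on this read-out lower numbers stand for lower oral bioavailability and higher numbers for higher oral bioavailability. Compound 1 `COC(=O)c1ccccc1-c1ccc([C@@H](C)Nc2nccc(C)c2NC(=O)CC#N)cc1` carries a nitrile on its amide chain and a methyl on the carbon that links the aromatic ring to the amine; in this assay compound 1 gives 27%. Compound 2 `COC(=O)c1ccccc1-c1ccc(CNc2nccc(C)c2NC(=O)CC(F)(F)F)cc1` carries a trifluoromethyl on its amide chain and only a hydrogen on that linking carbon; in this assay compound 2 gives 40%, the highest of the two numbers and beyond the scatter from the lower one. Among the measured compounds shown here, since the two differ in two places at once, no single step between them can be read off.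

Compound 3 `COC(=O)c1ccccc1-c1ccc([C@@H](C)Nc2nccc(C)c2NC(=O)CC(F)(F)F)cc1` keeps the trifluoromethyl chain of compound 2 and changes one thing: methyl in place of hydrogen on a saturated chain carbon bound to an aromatic carbon and a nitrogen on an aromatic ring. For the measured compounds named here, no measured pair isolates this change, so compound 1 with its own methyl gives only a loose hint. The expected step of a number 7 percentage points lower from compound 2 to compound 3 (within the scatter) is a small drop that stays within the scatter. Compound 3 is therefore estimated at 33%, with a range from 15% to 50%.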

Compound 3, oral bioavailability: 17%
The estimate for compound 3 lay 16 percentage points above the measured number; measured number inside the range.
By their numbers in this assay, from the lowest: compounds 3 and 1 (each within the scatter of the next); then compound 2.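

In this assay the methyl in place of hydrogen on a saturated chain carbon bound to an aromatic carbon and a nitrogen on an aromatic ring now has a step of its own, a number 23 percentage points lower from compound 2 to compound 3 (beyond the scatter), so adding this single carbon to the chain clearly costs oral bioavailability with the trifluoromethyl chain in place. The other place can now be read as well: with the methyl present on both compounds, trifluoromethyl in place of cyano on a saturated chain carbon bound to a carbonyl carbon gives a number 10 percentage points lower from compound 1 to compound 3 (within the scatter), so the nitrile and the trifluoromethyl cannot be told apart on this read-out, and only the methyl change stands out among these compounds. Nothing shown here gives a reason for the size of the methyl step.

Whether the methyl costs as much with a nitrile on the amide chain stays open, since the compounds shown hold no nitrile partner with hydrogen on the linking carbon. Also open, going by these compounds, is how a larger group on that carbon, such as an ethyl or a hydroxymethyl, would compare with the methyl.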